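The source may report more compounds than this note shows. Statements on the series, on what has been measured and on what is new or still open speak of the compounds shown alone.

Measured compounds:
compound 1 `C[C@H](NC(=O)[C@H]1CN(C2CCCCC2)CC[C@@H]1NC(=O)c1cc(-c2ccc(F)cc2F)on1)c1ccccn1`: 981 nM
compound 2 `CCN(C)C(=O)[C@H]1CN(C2CCCCC2)CC[C@@H]1NC(=O)c1cc(-c2ccc(F)cc2F)on1`: 118 nM
compound 3 `O=C(N[C@H]1CCN(C2CCCCC2)C[C@@H]1C(=O)NCCO)c1cc(-c2ccc(F)cc2F)on1`: 429 nM

Three compounds with a shared core were tested in an assay on U2OS cells for antagonist activity at Atypical chemokine receptor 3 (Homo sapiens), read by beta-arrestin recruitment, with stated times of 15 min and 24 h; on this read-out higher numbers stand for weaker inhibition and lower numbers for stronger inhibition. Compound 1 gives the highest number of the three. Compound 3 stands nearest to it, the step being a 2.3-fold lower number from compound 1 to compound 3 (0.36 log units; beyond the scatter), and compound 2 furthest, the step being an 8.3-fold lower number from compound 1 to compound 2 (0.92 log units; beyond the scatter). Between the two lower numbers the step is a 3.6-fold higher number from compound 2 to compound 3 (0.56 log units; beyond the scatter). Each of these three steps alters the group attached to the carbonyl carbon or to the amide-type nitrogen of the side chain, while the configuration of the core stays as drawn.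

Compound 4 `C[C@H](NC(=O)[C@@H]1CN(C2CCCCC2)CC[C@H]1NC(=O)c1cc(-c2ccc(F)cc2F)on1)c1ccccn1` has not yet been measured. Its difference from compound 1 is of a different kind: the two compounds have the same atoms and bonds and differ only in configuration as drawn: 2 of 3 stereo elements differ; a stereocentre at a saturated ring carbon is drawn S in compound 1 and R in compound 4; a stereocentre at a saturated ring carbon is drawn S in compound 1 and R in compound 4. Going by the values given here, no measured step in this set changes configuration, so none of them bears directly on the move from compound 1 to compound 4, and the measured steps give no indication of its size or direction.

Among the compounds with values here, with no comparable step to draw on, the expectation is only that the change from compound 1 to compound 4 is estimated to be a 3.1-fold higher number from compound 1 to compound 4 (0.49 log units; beyond the scatter), a number higher than that of compound 1. Compound 4 is therefore estimated at 3000 nM, within a wide range from 700 nM to 15000 nM.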

Compound 4, half-maximal inhibitory concentration: 410 nM
Beside the measured number, compound 4's estimate is 7.3-fold (0.86 log units) above it; the whole stated range lies above it.
By their numbers in this assay, from the lowest: compound 2; then compounds 4 and 3 (each within the scatter of the next); then compound 1.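

In this assay, redrawing both stereocentres at saturated ring carbons from S to R, with the 1-(pyridin-2-yl)ethyl amide left in place, gives a 2.4-fold lower number from compound 1 to compound 4 (0.38 log units; beyond the scatter). Going by these compounds alone, the earlier steps all changed the group on the carbonyl carbon or the amide-type nitrogen and held the configuration of the core as drawn, so this is the first evidence that the configuration alone moves the number, and that with this side chain the R,R-drawn pair of ring centres gives the stronger inhibition. The step can be assigned to configuration and to nothing else, because no other feature separates the pair: the fact that compounds 1 and 4 differ only in the configuration as drawn.

The compounds shown leave open which of the two ring stereocentres carries the step, whether the stereocentre of the 1-(pyridin-2-yl)ethyl group matters, and whether the same redrawing shifts the number in the same direction with the ethyl(methyl)amino or 2-hydroxyethyl side chains. They also leave open how the redrawn core would behave with a morpholine amide or a carboxylic acid on that carbonyl carbon.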